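The source may report more compounds than this note shows. Statements on the series, on what has been measured and on what is new or still open speak of the compounds shown alone.

Within the data shown here, in a functional assay on HCT-116 cells (Homo sapiens) for cytotoxicity, read by MTT assay, with a stated time of 48 h, in the presence of a further agent that is not named here (on this read-out higher numbers stand for an effect only at larger amounts of compound and lower numbers for an effect already at smaller amounts), compound 1 (`COc1ccc(-c2cc(NNC(=O)Nc3cc(Cl)nc(Cl)c3)nc3c2cnn3C)cc1`) gives 12300 nM and compound 2 (`CC(C)c1cc(NNC(=O)Nc2cc(Cl)nc(Cl)c2)nc2c1c(C(F)(F)F)nn2C`) gives 27200 nM as the only numbers so far. Compound 2 holds the higher of the two, and its gap to compound 1 lies beyond the scatter.

Compound 3 (`CC(C)c1cc(NNC(=O)Nc2cc(Cl)nc(Cl)c2)nc2c1cnn2C`) has not yet been measured. It departs from compound 2 by a single change (hydrogen in place of trifluoromethyl on an aromatic carbon): hydrogen in place of trifluoromethyl on an aromatic carbon of the five-membered aromatic ring, two ring bonds from the ring atom that bears a methyl group.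

Among the measured compounds shown here, no measured step isolates this change, so its size cannot be read directly from the data. In this assay no shift beyond the scatter is expected, and the expected 1.5-fold lower number from compound 2 to compound 3 (0.18 log units; within the scatter) is a small one toward a lower number. This expectation has only two reference points, compound 1 at 12300 nM and compound 2 at 27200 nM in the same read-out. For compound 3 the estimated value is 18000 nM with an expected range from 7000 nM to 45000 nM as the working figure.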

Compound 3, half-maximal effective concentration: 17200 nM
Compound 3: the middle estimate sits 1.0-fold (0.02 log units) above what was measured; low and high end bracket the measured number.
By their numbers in this assay, from the lowest: compounds 1, 3 and 2 (each within the scatter of the next, the first and the last beyond it).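

In this assay, hydrogen in place of trifluoromethyl on the aromatic carbon of the five-membered aromatic ring gives a 1.6-fold lower number from compound 2 to compound 3 (0.20 log units; within the scatter), so this read-out does not separate the two groups at this position, at least on the background of compound 3 with its isopropyl group. Isopropyl in place of 4-methoxyphenyl on an aromatic carbon gives a 1.4-fold higher number from compound 1 to compound 3 (0.15 log units; within the scatter), so that change also stays within the scatter, and each of the two single-place steps now available is small in this read-out. No measurement shown bears on the reasons for the size of either step.

On these data alone, whether a nitrile, an amine or a carboxylic acid on the carbon that carries hydrogen in compound 3 would give a step beyond the scatter remains open, since only hydrogen and trifluoromethyl can be compared there. Also open, as far as these compounds go, is whether a methyl group, a longer chain or a phenyl ring without the methoxy group, on the carbon that carries isopropyl in compound 3, would separate from isopropyl and 4-methoxyphenyl.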